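Methoxy in Place of Fluoro on the Aryl of Compound 3

The source may hold more compounds than are shown below. What is called first, only, known or untested is meant among the compounds shown, and "the series" means these compounds.

Measured in a functional assay on SJSA-1 cells (Homo sapiens) for inhibition, read by CCK-8 assay, with a stated time of 72 h, tested at 1 uM; a lower number here means less inhibition, a higher number more inhibition at the concentration tested (going by the name of the read-out):
compound 1, `COc1ccccc1N1C(=O)CSC1c1cc(F)cc(C(=O)O)c1`, gives 0%;
compound 2, `COc1ccc(OC)c(N2C(=O)CSC2c2cccc(C(=O)NCCCCc3ccccc3)c2)c1`, gives 48%;
compound 3, `COc1cc(F)ccc1N1C(=O)CSC1c1cccc(C(=O)NCCCCc2ccccc2)c1`, gives 77%.

Compound 3 stands highest of the three numbers in this assay. Compound 2 lies nearest to it, and the gap between them is beyond the scatter; compound 1 lies furthest, with its zero reading far below compound 3.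

Compound 4, `COc1ccc(N2C(=O)CSC2c2cccc(C(=O)NCCCCc3ccccc3)c2)c(OC)c1`, is the unmeasured member. It differs from compound 3 by methoxy in place of fluoro on an aromatic carbon. Among the compounds with values here, only one measured step bears on this change, the one that swaps the aryl group on the amide-type nitrogen in the ring: a number 29 percentage points higher from compound 2 to compound 3 (beyond the scatter). That step went from 2,5-dimethoxyphenyl to 4-fluoro-2-methoxyphenyl and gained inhibition; compound 4 moves back to a dimethoxyphenyl, here 2,4-dimethoxyphenyl, so the expectation is a loss of part of that gain. Because a number 29 percentage points higher from compound 2 to compound 3 (beyond the scatter) was modest, the expected step is also modest and downward, a number 22 percentage points lower from compound 3 to compound 4 (beyond the scatter). Compound 4 is estimated at 55%, within a range from 35% to 75%.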

Compound 4, a percentage reported as inhibition, at one concentration (the size of the read-out at that concentration, not a potency): 85%
Beside the measured number, compound 4's estimate is 30 percentage points below it; measured number outside the range, above it.
By their numbers in this assay, from the lowest: compound 1; then compound 2; then compounds 3 and 4 (each within the scatter of the next).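

In this assay, the carbon para to a large group accepts methoxy in place of fluoro with no change that can be told from the scatter, a number 8 percentage points higher from compound 3 to compound 4 (within the scatter), so a second methoxy on the aryl does not by itself hold inhibition down. The placement of that methoxy does matter, since the 2,4-dimethoxyphenyl group in place of 2,5-dimethoxyphenyl gives a number 37 percentage points higher from compound 2 to compound 4 (beyond the scatter), and the earlier gain from the fluoro compound therefore need not depend on fluoro at all. Nothing measured here explains this difference between the two dimethoxyphenyl groups.

The compounds shown leave open how an ethoxy, a chloro or a dimethylamino group would read at this same carbon. They also leave open whether the 2,4-dimethoxyphenyl result would hold with a shorter chain on the amide in place of phenylbutyl.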